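This account rests on a few compounds, and the source may have more. Where it says the series, first, only, none or still open, it means among the compounds named here.

Working notes on the series. Among the measured compounds shown here, in a functional assay on Bel-7402 cells (Homo sapiens) for cytotoxicity, read by MTT assay (on this read-out lower numbers stand for stronger inhibition and higher numbers for weaker inhibition), compound 3 `COc1cc(/C=C/C(=O)c2sc(Nc3ccccc3C)nc2C)cc(OC)c1OC` gives 10300 nM, the only plain number among the three values shown. For compound 1 `COc1cc(/C=C/C(=O)c2sc(Nc3ccc(Cl)cc3)nc2C)cc(OC)c1OC` the value is a limit, > 25000 nM. For compound 2 `COc1cc(/C=C/C(=O)c2sc(Nc3ccc(Cl)c(Cl)c3)nc2C)cc(OC)c1OC` the value is likewise a limit, > 25000 nM. Against the limit of > 25000 nM in this assay, at which 2 of the 3 values shown sit, the steps of an at least 2.4-fold lower number from compound 1 to compound 3 (0.38 log units; beyond the scatter) and an at least 2.4-fold lower number from compound 2 to compound 3 (0.38 log units; beyond the scatter) are read as lower bounds, while the step that the two limits leave unreadable from compound 1 to compound 2 cannot be read. Compound 4 `COc1cc(/C=C/C(=O)c2sc(Nc3cccc(C)c3)nc2C)cc(OC)c1OC` differs from compound 3 by 3-methylphenyl in place of 2-methylphenyl on a nitrogen on an aromatic ring. For the measured compounds named here, both readable steps exchange the whole aryl group and carry chloro, so no measured step covers a move of methyl within the ring. The step of a 1.0-fold lower number from compound 3 to compound 4 (0.01 log units; within the scatter) is therefore expected to stay within the scatter. Compound 4 is expected near 10000 nM, between 4000 nM and 25000 nM, in this assay.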

Compound 4, half-maximal inhibitory concentration: > 25000 nM
Compound 4 gave a limit, no number; the forecaster's own chance of this, stated with the estimate: 30%; middle value at least 2.5-fold (0.39 log units) from the limit.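

Same atoms, joined differently: 3-methylphenyl in place of 2-methylphenyl gives an at least 2.4-fold higher number from compound 3 to compound 4 (0.38 log units; beyond the scatter) in this assay, so the place of the methyl on the phenyl ring alone changes the read-out. Among the compounds shown here, no earlier step isolated that move. The value of compound 4 is a limit, so this step is a lower bound and the steps from compound 1 and from compound 2 to compound 4 cannot be read, because these values sit at the same limit: the limit of > 25000 nM in this assay, at which 3 of the 4 values shown sit.

On these data alone, whether 2-ethylphenyl or 2-chlorophenyl would keep a plain number as 2-methylphenyl does stays open, as does where 4-methylphenyl falls.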